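Formyl to carboxy on two chain lengths

The source may report more compounds than this note shows. Statements on the series, on what has been measured and on what is new or still open speak of the compounds shown alone.

The study compares compound 1 `Cn1c(Cc2nn(CCC=O)c(=O)c3ccccc23)nnc1SCC(=O)Nc1ccc(Cl)cc1Cl`, compound 2 `Cn1c(Cc2nn(CCC(=O)O)c(=O)c3ccccc23)nnc1SCC(=O)Nc1ccc(Cl)cc1Cl` and compound 3 `Cn1c(Cc2nn(CCC=O)c(=O)c3ccccc23)nnc1SCCCCCCCC(=O)Nc1ccc(Cl)cc1Cl` in an assay on 32D cells for inhibition of interleukin-15 (Mus musculus), read by resazurin assay, with stated times of 30 min and 2.5 days, in the presence of a further agent that is not named here; a higher number here means a weaker inhibitor, a lower number a stronger inhibitor. In this assay compound 1 gives 30000 nM. Compound 2 reaches only a limit of this assay, > 30000 nM, and no number. Compound 3 gives 11700 nM, the lower of the two numbers that are known, and its gap to compound 1 lies beyond the usual scatter.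

The change from compound 1 to compound 2 is hydroxy in place of hydrogen on a carbonyl carbon, and it made a step of a number no lower from compound 1 to compound 2 (the limit leaves the size open). The size of that step is not readable because of the limit of > 30000 nM in this assay, at which 1 of the 3 values shown sits.

Compound 3 and compound 1 share the same change at the carbonyl end, but the difference between their two cores is not broken down here.

Compound 4 `Cn1c(Cc2nn(CCC(=O)O)c(=O)c3ccccc23)nnc1SCCCCCCCC(=O)Nc1ccc(Cl)cc1Cl` has not yet been measured in this assay. It differs from compound 3 by hydroxy in place of hydrogen on a carbonyl carbon, the same change, at the same place, as that between compound 1 and compound 2. Compound 4 is therefore expected to give a number no lower than compound 3, with a step estimated at a 2.1-fold higher number from compound 3 to compound 4 (0.33 log units; beyond the scatter), resting on the step from compound 1 to compound 2 and on the limit that compound 2 met. In this assay compound 4 is expected to give about 25000 nM, within a range from 12000 nM to 60000 nM, with a fair chance that only a limit is reported.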

Compound 4, half-maximal inhibitory concentration: > 30000 nM
Compound 4: only a limit was reported; the forecaster's own chance of this, stated with the estimate: 40%; middle value at least 1.2-fold (0.07 log units) away from the limit.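

Compound 4 reaches only a limit of this assay, > 30000 nM. On the core of compound 3, the change from 2-formylethyl to 2-carboxyethyl still gives a readable lower bound, an at least 2.5-fold higher number from compound 3 to compound 4 (0.40 log units; beyond the scatter), and it points the same way as the step on the core of compound 1, so within these two pairs the change carries over from one core to the other in direction: the same change on two cores in this assay, a number no lower (the limit leaves the size open) from compound 1 to compound 2 and an at least 2.5-fold higher number (0.40 log units; beyond the scatter) from compound 3 to compound 4; the limit leaves it open whether they differ This does not show that the change has the same size on both cores, or how large it truly is on either, because both carboxy compounds stop at the limit of the assay: the limit of > 30000 nM in this assay, at which 2 of the 4 values shown sit.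

The compounds shown leave open how a methyl ester, a primary amide or an amine in place of the carboxy group would read in this assay, and whether any of them would stay on the measurable side of that limit. They also leave open whether the same change behaves alike on a chain of intermediate length, since only these two cores are shown, and two pairs set no rule for the wider series.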